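A few compounds are considered here, and "the series" means these few. Any claim that something is new, unique, unknown or untested is made for them only; others in the source may bear on it.

Measured compounds:
compound 1, `Cc1nc(C)c([C@H](OC(C)(C)C)C(=O)O)c(N2CCC(C)(C)CC2)c1-c1ccc(OCCc2cc(F)c(F)cc2F)cc1`, in an ADME assay on microsomes from liver (Rattus norvegicus) for metabolic stability, read by LC-MS, tested at 0.5 uM (a lower number here means that the compound disappears faster, a higher number that the compound lasts longer), gives > 2 h
compound 2, `Cc1nc(C)c([C@H](OC(C)(C)C)C(=O)O)c(N2CCC(C)(C)CC2)c1-c1ccc(CCCc2ccc(F)cc2)cc1`, in this assay gives > 2 h

The value of compound 1 is a limit of the assay, not a number. The value of compound 2 is likewise only a limit. The step that the two limits leave unreadable from compound 1 to compound 2 therefore cannot be sized; both values sit at the limit of > 2 h in this assay, at which 2 of the 2 values shown sit. Compound 3, `Cc1nc(C)c([C@H](OC(C)(C)C)C(=O)O)c(N2CCC(C)(C)CC2)c1-c1ccc(OCCCc2ccc(F)cc2)cc1`, differs from compound 2 by 3-(4-fluorophenyl)propoxy in place of 3-(4-fluorophenyl)propyl on an aromatic carbon. Within the data shown here, no measured step resolves a change of this kind, and compound 2 already stands at the limit. Compound 3 is thus expected to stay at or near that limit, a step that the limit leaves unreadable from compound 2 to compound 3. The estimate for compound 3 in this assay is 2.5 h, in the range 1 h to 6 h.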

Compound 3, half-life: > 2 h
Compound 3: a limit, no number; the forecaster's own chance of this, stated with the estimate: 70%; the middle value is on the limit's open side.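

Compound 1, compound 2 and compound 3 each give only a limit, not a number, in this assay, so no step between them can be read: the limit of > 2 h in this assay, at which 3 of the 3 values shown sit.

From the compounds shown here alone, the actual half-life of each compound, and whether the differences between them change it, remain open.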